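Amino in place of the amidine on the formyl-bearing ring

The source may hold more compounds than are shown below. What is called first, only, known or untested is meant among the compounds shown, and "the series" means these compounds.

Three compounds have numbers in a functional assay on NCI-H226 cells (Homo sapiens) for inhibition, read by MTT assay, with a stated time of 72 h; a lower number here means a stronger inhibitor of growth, a higher number a weaker inhibitor of growth. Compound 1 `Cc1ccc(-c2cc(N)n(-c3cccc(Cl)c3)n2)cc1` gives 63500 nM, compound 2 `Cc1ccc(-c2nn(-c3cccc(Cl)c3)c(/N=C/N(C)C)c2C=O)cc1` gives 8900 nM, and compound 3 `Cc1ccc(-c2nn(-c3ccc(Br)cc3)c(/N=C/N(C)C)c2C=O)cc1` gives 8200 nM. Compound 2 therefore has the second highest of the three numbers: its nearest neighbour is compound 3, and the step of a 1.1-fold lower number from compound 2 to compound 3 (0.04 log units; within the scatter) lies within the scatter, while compound 1 stands furthest away with a number far higher than that of compound 2.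

Compound 4 `Cc1ccc(-c2nn(-c3cccc(Cl)c3)c(N)c2C=O)cc1` differs from compound 2 by one nitrogen atom in place of a group of 5 heavy atoms (3 carbon, 2 nitrogen; no ring), on an aromatic carbon. Within the data shown here, none of the measured steps covers this change: the one step on record, from compound 2 to compound 3, alters the group on the aromatic nitrogen and leaves the amidine untouched. Compound 1 carries an amino group but lacks the formyl group, so it only shows what its own number shows. Among the measured compounds shown here, with no step bearing directly on the change, the size of the step in this assay is uncertain, and a move towards a higher number is expected, a 2.2-fold higher number from compound 2 to compound 4 (0.35 log units; beyond the scatter). Compound 4 is therefore estimated at 20000 nM, within a range from 7000 nM to 60000 nM.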

Compound 4, concentration for 50% growth inhibition: 71800 nM
Beside the measured number, compound 4's estimate is 3.6-fold (0.56 log units) below it; measured number outside the range, above it.
By their numbers in this assay, from the lowest: compounds 3 and 2 (each within the scatter of the next); then compounds 1 and 4 (each within the scatter of the next).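

In this assay, this aromatic carbon proves sensitive to the change: with the formyl group and the 3-chlorophenyl group held in place, amino in place of the group of 5 heavy atoms gives an 8.1-fold higher number from compound 2 to compound 4 (0.91 log units; beyond the scatter), a step beyond the scatter and far larger than the one on the aromatic nitrogen. With amino on that carbon, adding the formyl group gives a 1.1-fold higher number from compound 1 to compound 4 (0.05 log units; within the scatter), which lies within the scatter, so among these compounds formyl alone brings no change in the number. No measured evidence accounts for the size of either step.

From the compounds shown here alone, it remains open whether the step from the larger group to amino would be the same with 4-bromophenyl on the aromatic nitrogen. Also open, going by these compounds, is how a dimethylamino group, an acetamide or a longer chain would read on this aromatic carbon.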